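The source may report more compounds than this note shows. Statements on the series, on what has been measured and on what is new or still open speak of the compounds shown alone.

Compound 1 `CCCCCc1c(C(C)C)nc(C(C)C)c(CO)c1-c1ccc(CC)cc1` belongs to a set of three close relatives tested in an assay on CHO cells for inhibition of Glucagon receptor (Homo sapiens), tested at 20 uM; a lower number here means less inhibition, a higher number more inhibition at the concentration tested (going by the name of the read-out). Compound 1 gives 42%, the second highest of the three numbers. Compound 2 `CCCCCc1c(C(C)C)nc(C(C)C)c(CO)c1-c1cccc(C)c1` gives 46%, so the two lie within the scatter of each other. Compound 3 `CCCCCc1c(C(C)C)nc(C(C)C)c(CO)c1-c1ccccc1OC` gives 27%, and the step of a number 15 percentage points lower from compound 1 to compound 3 (beyond the scatter) is a modest drop. Compound 4 `CCCCCc1c(C(C)C)nc(C(C)C)c(CO)c1-c1ccc(C(F)(F)F)cc1` is not yet measured; it differs from compound 1 in one place: trifluoromethyl in place of ethyl on an aromatic carbon. Among the measured compounds shown here, no measured step touches the ethyl itself. The two changes seen on the same six-membered aromatic ring of carbon only were a number 4 percentage points higher from compound 1 to compound 2 (within the scatter) and a number 15 percentage points lower from compound 1 to compound 3 (beyond the scatter), one flat and one a modest fall. For compound 4 the step of a number 2 percentage points lower from compound 1 to compound 4 (within the scatter) is therefore expected to stay within the scatter. Compound 4 is estimated at 40%, between 25% and 55%.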

Compound 4, a percentage reported as inhibition, at one concentration (the size of the read-out at that concentration, not a potency): 35%
For compound 4 the middle estimate is 5 percentage points above the measured one; measured number inside the range.
By their numbers in this assay, from the lowest: compounds 3, 4, 1 and 2 (each within the scatter of the next, the first and the last beyond it).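

Among the compounds shown here, this is the first change made on the ethyl itself: in this assay, trifluoromethyl in place of ethyl gives a number 7 percentage points lower from compound 1 to compound 4 (within the scatter). At this spot, para to a large group, the larger trifluoromethyl, with fluorine atoms instead of a plain carbon chain, therefore leaves the reading within the usual spread of repeat measurements. No measured evidence here bears on why the two groups read alike.

As far as these compounds go, whether an amine, a carboxylic acid or a chain longer than ethyl would be accepted at this spot remains open. Readings at one concentration also leave the potency of compound 1 and compound 4 unknown.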